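This account rests on a few compounds, and the source may have more. Where it says the series, first, only, none or still open, it means among the compounds named here.

The measured compounds:

compound 1 `O=C(O)C1CC(=O)N(c2ccc(OCc3ccc(Cl)cc3Cl)cc2)C1` — in a functional assay on cells for agonist activity at Free fatty acid receptor 1 (Mus musculus), read by FLIPR and calcium flux, with a stated time of 100 s (a higher number here means that more compound is needed for the effect, a lower number that less compound is needed), compound 1 gives a limit of > 33000 nM, not a number.
compound 2 `O=C(O)C[C@@H]1CCCN1c1ccc(OCc2ccc(Cl)cc2Cl)cc1` — in this assay compound 2 gives 4500 nM.

Compound 2 stands alone on the numbers in this assay: its value is the only actual number shown, while the other entry is a limit, namely (the limit of > 33000 nM in this assay, at which 1 of the 2 values shown sits). The step under consideration runs from compound 2 to compound 3 `O=C(O)C[C@H]1CCCN1c1ccc(OCc2ccc(Cl)cc2Cl)cc1`. The change is the two compounds have the same atoms and bonds and differ only in configuration as drawn: 1 of 1 stereo elements differ; a stereocentre at a saturated ring carbon is drawn S in compound 2 and R in compound 3; the two compounds have the same atoms and bonds and differ only in configuration as drawn. Among the compounds with values here, no step between two measured compounds is available to say how much a change of this kind moves the number in this assay. An enantiomer can sit anywhere from close to its partner to far weaker, so a step beyond the scatter toward a higher number is expected, yet with little confidence in its size. On that basis compound 3 is estimated at 15000 nM, within a wide range from 2500 nM to 60000 nM, which means an expected step of a 3.3-fold higher number from compound 2 to compound 3 (0.52 log units; beyond the scatter).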

Compound 3, half-maximal effective concentration: > 17000 nM
Compound 3 was reported as a limit; the forecaster's own chance of this, stated with the estimate: 40%; middle value at least 1.1-fold (0.05 log units) from the limit.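

In this assay compound 3 gives > 17000 nM, which is a limit of the assay and not a number. Even so, the pair can be read in one direction, with an at least 3.7-fold higher number from compound 2 to compound 3 (0.57 log units; beyond the scatter), so at this saturated ring carbon the form drawn S needs less compound than the form drawn R, a point that compound 1, itself only a limit, could not show. The shift can be tied to this stereocentre alone, because nothing else separates the pair: the fact that compounds 2 and 3 differ only in the configuration as drawn.

The compounds shown leave open how large the step really is, since only its lower bound can be read. They also leave open whether the same order between S and R would hold with a tetrazole in place of the carboxylic acid, or with a longer chain carrying that acid.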